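The compounds below may be only part of what the source reports. "The series", "measured", "known", "first", "only" and "open" are said of these compounds alone.

In a functional assay on A549 cells (Homo sapiens) for cytotoxicity, with a stated time of 48 h (on this read-out lower numbers stand for stronger inhibition and higher numbers for weaker inhibition), compound 1 `CCCOc1ccc2oc(/C=C/[S+](C)[O-])cc(=O)c2c1` gives 1100 nM, compound 2 `Cc1ccc2oc(/C=C/[S+](C)[O-])cc(=O)c2c1` gives 1700 nM, and compound 3 `C[S+]([O-])/C=C/c1cc(=O)c2cc(F)ccc2o1` gives 2100 nM. Compound 1 has the lowest number of the three, but the steps of a 1.5-fold higher number from compound 1 to compound 2 (0.19 log units; within the scatter) and a 1.9-fold higher number from compound 1 to compound 3 (0.28 log units; within the scatter) are both within the scatter, so the three compounds cannot be told apart. Compound 4 `CC(C)CC(=O)Oc1ccc2oc(/C=C/[S+](C)[O-])cc(=O)c2c1` differs from compound 1 by isobutylcarbonyl in place of propyl on an oxygen on an aromatic ring. Among the measured compounds shown here, no measured step changes the group on that oxygen; the steps that exist, a 1.5-fold higher number from compound 1 to compound 2 (0.19 log units; within the scatter), a 1.9-fold higher number from compound 1 to compound 3 (0.28 log units; within the scatter) and a 1.2-fold higher number from compound 2 to compound 3 (0.09 log units; within the scatter), replace the whole aromatic substituent and all stay within the scatter. In this assay compound 4 is therefore expected near compound 1, an estimated 1.4-fold higher number from compound 1 to compound 4 (0.13 log units; within the scatter), giving 1500 nM within 600 nM to 4000 nM.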

Compound 4, half-maximal inhibitory concentration: 2300 nM
Compound 4: middle estimate off by 1.5-fold (0.19 log units), on the low side; low and high end bracket the measured number.
By their numbers in this assay, from the lowest: compounds 1, 2, 3 and 4 (each within the scatter of the next, the first and the last beyond it).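

In this assay, among the compounds shown here, replacing propyl with isobutylcarbonyl on the oxygen is the first change here to pass the scatter, though only modestly, with a 2.1-fold higher number from compound 1 to compound 4 (0.32 log units; beyond the scatter). The other two comparisons stay within the scatter, with a 1.4-fold higher number from compound 2 to compound 4 (0.13 log units; within the scatter) and a 1.1-fold higher number from compound 3 to compound 4 (0.04 log units; within the scatter), so the (isobutylcarbonyl)oxy group cannot be told apart from methyl or fluoro. Nothing available explains the step from propoxy.

The compounds shown leave open whether the carbonyl or the size of the chain matters more. A butyl chain on that oxygen, set against an acetyl group, would help separate the two.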